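Methyl to Hydrogen on a Phenolic Oxygen, Twice

The source may report more compounds than this note shows. Statements on the series, on what has been measured and on what is new or still open speak of the compounds shown alone.

In a functional assay on SW480 cells (Homo sapiens) for antiproliferative activity, read by sulforhodamine B assay, with a stated time of 48 h (on this read-out higher numbers stand for weaker inhibition and lower numbers for stronger inhibition), three compounds have been measured. Compound 1 `COc1ccc(/C=C/C(=O)c2ccccc2-c2cccc(F)c2)cc1OC` gives 160 nM. Compound 2 `COc1ccc(/C=C/C(=O)c2ccccc2-c2cccc(F)c2)cc1O` gives 10 nM. Compound 3 `COc1ccc(C(=O)/C=C/c2ccccc2-c2ccc(F)cc2)cc1OC` gives 8300 nM, the highest of the three numbers, standing beyond the scatter from both compound 1 and compound 2.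

Compound 1 and compound 2 differ in one place, (hydrogen in place of methyl on an oxygen on an aromatic ring), and the step is a 16-fold lower number from compound 1 to compound 2 (1.20 log units; beyond the scatter). Compound 3 is built from the same atoms as compound 1 joined differently; the difference between the two cores is not broken down here.

Compound 4 `COc1cc(C(=O)/C=C/c2ccccc2-c2ccc(F)cc2)ccc1O` has not been measured. It differs from compound 3 by hydrogen in place of methyl on an oxygen on an aromatic ring, and the place of the change reads the same as for the pair of compound 1 and compound 2, so it is the same change, made for the second time among the compounds shown. Whether it acts alike on the core of compound 3, whose number sits far from that of compound 1, is not known from these data.

Compound 4 is expected to give a lower number than compound 3, since compound 1 to compound 2 gave a 16-fold lower number from compound 1 to compound 2 (1.20 log units; beyond the scatter), but with a wider range in view of the different core; the step is estimated as an 8.3-fold lower number from compound 3 to compound 4 (0.92 log units; beyond the scatter). Compound 4 is estimated at 1000 nM, between 250 nM and 4500 nM.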

Compound 4, half-maximal inhibitory concentration: 4200 nM
For compound 4 the middle estimate is 4.2-fold (0.62 log units) below the measured one; the range from low to high includes it.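

In this assay, the replacement of methoxy by hydroxy on the aromatic ring does not carry over at one size between the two cores: the same change on two cores in this assay, a 16-fold lower number (1.20 log units; beyond the scatter) from compound 1 to compound 2 and a 2.0-fold lower number (0.30 log units; within the scatter) from compound 3 to compound 4, 8.1-fold (0.91 log units) apart, beyond the scatter of two such steps

On the core of compound 1, the change is large, while on the other core it comes to a 2.0-fold lower number from compound 3 to compound 4 (0.30 log units; within the scatter), so the hydroxy compound there cannot be told apart from its methoxy partner. For the compounds shown here, this shows that the large step seen on the first core cannot be taken as a fixed increment, but it does not show which difference between the two cores accounts for the gap, since the cores differ as a whole and only one pair stands on each.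

The compounds shown leave open how the change would behave on a third core, and so whether either of the two steps is the more typical one. They also leave open what other groups on that oxygen or in its place, such as an ethyl group, a longer chain, or an amine, would do on each of the two cores.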